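The source may report more compounds than this note shows. Statements on the series, on what has been measured and on what is new or still open speak of the compounds shown alone.

In a functional assay on MDA-MB-436 cells (Homo sapiens) for antiproliferative activity, read by MTT assay, with a stated time of 24 h (on this read-out lower numbers stand for stronger inhibition and higher numbers for weaker inhibition), two compounds have been read so far. Compound 1 `CC(C)(C)c1ccc(C(CC(=O)O)NS(=O)(=O)c2ccccc2)cc1` gives > 100000 nM, which is a limit of the assay and not a number. Among the compounds with values here, compound 2 `CC(C)(C)c1ccc(C(CC(=O)O)NS(=O)(=O)c2ccc(C(F)(F)F)cc2)cc1` gives 60100 nM, the only actual number so far. Within the data shown here, the one measured step, an at least 1.6-fold lower number from compound 1 to compound 2 (0.22 log units; that floor lies within the scatter), comes from trifluoromethyl in place of hydrogen on an aromatic carbon.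

Compound 3 `CC(C)(C)c1ccc(C(CC(=O)O)NS(=O)(=O)c2ccc(OC(F)(F)F)cc2)cc1` has not yet been measured in this assay. It differs from compound 2 by one change: trifluoromethoxy in place of trifluoromethyl on an aromatic carbon. Trifluoromethoxy replaces trifluoromethyl on an aromatic carbon, para to a large group.

Among the measured compounds shown here, only the step of an at least 1.6-fold lower number from compound 1 to compound 2 (0.22 log units; that floor lies within the scatter) bears on this change, since it concerns the same aromatic carbon. Its floor lies within the scatter, so it gives no firm size to carry over, and no clear direction either. Little change is therefore expected from the value of compound 2. The estimated 1.3-fold lower number from compound 2 to compound 3 (0.13 log units; within the scatter) is expected to stay within the scatter. For compound 3 the expected value is 45000 nM, with an estimated range from 15000 nM to 100000 nM.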

Compound 3, half-maximal inhibitory concentration: > 100000 nM
Compound 3: only a limit was reported; the forecaster's own chance of this, stated with the estimate: 20%; at least 2.2-fold (0.34 log units) between middle value and limit.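

At this position, on an aromatic carbon para to a large group, trifluoromethoxy in place of trifluoromethyl gives an at least 1.6-fold higher number from compound 2 to compound 3 (0.22 log units; that floor lies within the scatter), and so the change yields no firm size and the direction rests on a floor that does not clear the usual variation. In this assay, within the data shown here, compound 3 gives > 100000 nM, which is a limit of the assay and not a number, so the only readable value at this carbon still belongs to the trifluoromethyl group of compound 2. The step from compound 1 to compound 3 cannot be read, since both of its ends are limits, and most of the series now sits at a single boundary of the read-out: the limit of > 100000 nM in this assay, at which 2 of the 3 values shown sit.

The compounds shown leave open whether another group at this aromatic carbon, such as a nitrile, a chlorine atom or a methoxy group, would give a readable value, and how far compound 3 lies from compound 2. They also leave open what happens when the carboxylic acid of the shared core gives way to a primary amide or a methyl ester.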